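The compounds below may be only part of what the source reports. "The series", "measured", "known", "first", "only" and "open" are said of these compounds alone.

Compound 1 `Cc1cc(NC(=O)Nc2ccc(C)c(Cl)c2)c2ccccc2n1` is one of three ureas that share a core. In an ADME assay on HepG2 cells (Homo sapiens) for cytotoxicity, with a stated time of 72 h (a higher number here means that more compound is needed for the effect, a lower number that less compound is needed), compound 1 gives > 25000 nM, which is a limit of the assay and not a number. Compound 2 `Cc1cc(NC(=O)Nc2ccccc2C(F)(F)F)c2ccccc2n1` gives > 25000 nM, also a limit rather than a number. Compound 3 `Cc1ccc(NC(=O)Nc2cc(C)nc3ccccc23)cc1` gives > 25000 nM, again only a limit. The step that the two limits leave unreadable from compound 1 to compound 3 is thus unreadable, and the limit of > 25000 nM in this assay, at which 3 of the 3 values shown sit, is the whole of the evidence on cytotoxicity here. Compound 4 `Cc1cc(NC(=O)Nc2ccc(Cl)c(Cl)c2)c2ccccc2n1` differs from compound 1 by chloro in place of methyl on an aromatic carbon. Going by the values given here, no measured step reads out a size or direction for this change, so no step beyond the scatter is expected, and a limit is the likely outcome once more. Compound 4 is expected at 30000 nM, within 15000 nM to 60000 nM. The step that the limit leaves unreadable from compound 1 to compound 4 is expected to be flat.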

Compound 4, half-maximal effective concentration: 17000 nM
For compound 4 the middle estimate is 1.8-fold (0.25 log units) above the measured one; the range from low to high includes it.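

Going by these compounds alone, on an aromatic carbon ortho to a chloro group and para to a large group, chloro in place of methyl gives the first step in this assay with a readable floor: an at least 1.4-fold lower number from compound 1 to compound 4 (0.16 log units; that floor lies within the scatter). That floor does not by itself establish a change beyond the scatter. Compound 4 is the only compound here with a number and not a limit: the limit of > 25000 nM in this assay, at which 3 of the 4 values shown sit.

The full size of this step stays open, and the other steps among these compounds cannot be read. On these data alone, how an amine or a methoxy group at this position would read in this assay is also open.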